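A few compounds are considered here, and "the series" means these few. Any claim that something is new, unique, unknown or untested is made for them only; others in the source may bear on it.

Compound 1 `N=C(N)SCCCOc1oc(=O)c2cc(NC(=O)NCc3ccccc3)ccc2c1Cl`: 2.47 h
Compound 2 `N=C(N)SCCOc1oc(=O)c2cc(NC(=O)CCc3ccccc3)ccc2c1Cl`: 0.65 h

In an ADME assay for pharmacokinetics (a lower number here means that the compound disappears faster, a higher number that the compound lasts longer), compound 1 holds the higher of the two numbers at 2.47 h, and compound 2 gives 0.65 h, a gap that lies beyond the scatter. Compound 3 `N=C(N)SCCCOc1oc(=O)c2cc(N)ccc2c1Cl` keeps the core of compound 1 but carries hydrogen in place of benzylcarbamoyl on a nitrogen on an aromatic ring. Among the compounds with values here, no measured pair isolates this change, so the expectation is only a judgment, and a moderate fall is anticipated. The expected shift is a 2.1-fold lower number from compound 1 to compound 3 (0.31 log units; beyond the scatter). Compound 3 is estimated at 1.2 h, with an expected range of 0.4 h to 3 h.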

Compound 3, half-life: 1.5 h
Beside the measured number, compound 3's estimate is 1.3-fold (0.10 log units) below it; the measured number falls inside the stated range.
By their numbers in this assay, from the lowest: compound 2; then compounds 3 and 1 (each within the scatter of the next).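

Replacing benzylcarbamoyl with hydrogen on the nitrogen on the aromatic ring gives, in this assay, a 1.6-fold lower number from compound 1 to compound 3 (0.22 log units; within the scatter). Within the data shown here, this single-place comparison, which the earlier compounds did not offer, shows that the whole group, its six-membered aromatic ring included, can leave this nitrogen without a difference that stands clear of the scatter. No other measurement bears on this result. Going by these compounds, what remains open is whether an acetyl or a methyl on the same nitrogen would also stay within the scatter of compound 3, and whether a longer chain there would separate from compound 1.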